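Fluoro replaces the carboxy on compound 1's core

A few compounds are considered here, and "the series" means these few. Any claim that something is new, unique, unknown or untested is made for them only; others in the source may bear on it.

Compound 1 `O=C(O)c1ccc2c(O)c(C(=O)O)cnc2c1` is the weakest inhibitor among the three compounds measured in an assay on isolated protein with malate dehydrogenase, cytoplasmic (Sus scrofa) as the target (a lower number here means a stronger inhibitor, a higher number a weaker inhibitor), where compound 1 gives 1290000 nM. Its nearest neighbour is compound 3 `CC(=O)c1ccc2c(O)c(C(=O)O)cnc2c1`, which in this assay gives 912000 nM; the step of a 1.4-fold lower number from compound 1 to compound 3 (0.15 log units; within the scatter) exchanges methyl for hydroxy on the carbonyl carbon without a meaningful shift. Compound 2 `O=C(O)c1cnc2cc(OCCc3ccc(Br)cc3)ccc2c1O` is furthest away and gives 91200 nM, but it differs from compound 1 in more than one place, so only its value can be compared.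

Compound 4 `O=C(O)c1cnc2cc(F)ccc2c1O` arises from compound 1 through (fluoro in place of carboxy on an aromatic carbon). Among the measured compounds shown here, no measured step covers this exchange; the only step among the measured compounds, from compound 1 to compound 3, was within the scatter, and it suggests that altering the group on this carbon changes little. Compound 4 is therefore expected to show a step of a 1.2-fold higher number from compound 1 to compound 4 (0.07 log units; within the scatter), not beyond the scatter. For compound 4 the estimate in this assay is 1500000 nM, within a range from 400000 nM to 5000000 nM.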

Compound 4, half-maximal inhibitory concentration: 11000000 nM
The estimate for compound 4 lay 7.3-fold (0.87 log units) below the measured number; the measured number lies above the stated range.
By their numbers in this assay, from the lowest: compound 2; then compounds 3 and 1 (each within the scatter of the next); then compound 4.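

At this aromatic carbon the group turns out to matter in this assay: carboxy and acetyl gave values within the scatter of each other, but fluoro gives an 8.5-fold higher number from compound 1 to compound 4 (0.93 log units; beyond the scatter) and a 12-fold higher number from compound 3 to compound 4 (1.08 log units; beyond the scatter). Among the compounds shown here, these are the first changes at this carbon to move the number beyond the scatter, and both point towards a weaker inhibitor. Compound 1 and compound 3 both carry a carbonyl group here and compound 4 does not, though with so few compounds this is an observation about these three alone. Nothing available explains the shift. From the compounds shown here alone, it remains open whether the loss follows from fluoro itself or from the absence of a carbonyl group. An amide, a methyl ester, an amine or a chloro group at this carbon could help separate these two readings.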